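The source may report more compounds than this note shows. Statements on the series, on what has been measured and on what is new or still open speak of the compounds shown alone.

The shared core of compound 1 `COc1ccc(C(=O)/C=C/c2cccc(F)c2)c2c1C=CC(C)(C)O2` carries a double-bonded chain linking a carbonyl to a substituted phenyl ring. In a functional assay on K562 cells (Homo sapiens) for antiproliferative activity, read by MTT assay, with a stated time of 24 h (a lower number here means a stronger inhibitor, a higher number a weaker inhibitor), compound 1 gives only a limit of the assay, > 10000 nM. Compound 2 `COc1ccc(C(=O)/C=C/c2ccc(Br)cc2)c2c1C=CC(C)(C)O2` keeps that core and chain. In this assay compound 2 likewise returns a limit, > 10000 nM. Compound 3 `COc1ccc(C(=O)/C=C/c2ccc(N(c3ccccc3)c3ccccc3)cc2)c2c1C=CC(C)(C)O2` is the third measured member. In this assay compound 3 again reaches no number but a limit, > 10000 nM. The only single-point step among these three, a step that the two limits leave unreadable from compound 1 to compound 2, cannot be sized, because both of its values sit at the limit of > 10000 nM in this assay, at which 3 of the 3 values shown sit. Compound 2 therefore stands nowhere in particular on the numbers shown: it is one of three compounds whose values are all limits, and no ordering among them can be read.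

Compound 4 `COc1ccc(C(=O)/C=C/c2ccc(-n3ccnc3)cc2)c2c1C=CC(C)(C)O2` is the unmeasured member. It differs from compound 2 by 1H-imidazol-1-yl in place of bromo on an aromatic carbon. No measured step bears on this change in a readable way, since every shown value is a limit, so the size and direction of the step in this assay from compound 2 to compound 4 cannot be inferred from what is measured. Compound 4 is expected to follow the other three, with an estimated value of 20000 nM, between 5000 nM and 80000 nM. The step this estimate implies is a step that the limit leaves unreadable from compound 2 to compound 4, expected to remain within the limit.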

Compound 4, half-maximal inhibitory concentration: > 10000 nM
Compound 4: no number, only a limit (the forecaster's own chance of this, stated with the estimate: 70%); the middle value is on the limit's open side.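

Compound 4 gives > 10000 nM, which is a limit of the assay and not a number. No step from compound 2 to compound 4 can be read, because both values sit at: the limit of > 10000 nM in this assay, at which 4 of the 4 values shown sit.

Compound 1, compound 2, compound 3 and compound 4 leave open whether any group tried on the aromatic ring changes the result in this assay.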